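This account rests on a few compounds, and the source may have more. Where it says the series, first, only, none or still open, it means among the compounds named here.

Three members of one series have been read in a functional assay on HepG2 cells (Homo sapiens) for cytotoxicity, read by MTT assay, with a stated time of 24 h; a higher number here means a weaker inhibitor, a lower number a stronger inhibitor. Compound 1 `Cc1ccc(S(=O)(=O)N2C/C(=C\c3cccnc3)C(=O)/C(=C/c3ccccc3F)C2)cc1` gives 4200 nM. Compound 2 `Cc1ccc(S(=O)(=O)N2C/C(=C\c3cccnc3)C(=O)/C(=C/c3ccccc3C(F)(F)F)C2)cc1` gives 2930 nM. Compound 3 `O=C1/C(=C/c2cccnc2)CN(S(=O)(=O)c2ccc(C(F)(F)F)cc2)C/C1=C\c1ccccc1C(F)(F)F` gives 1710 nM. Compound 4 `O=C1/C(=C/c2cccnc2)CN(S(=O)(=O)c2ccc(F)cc2)C/C1=C\c1ccccc1C(F)(F)F` has no value yet in this assay.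

Compound 1 differs from compound 2 by fluoro in place of trifluoromethyl on an aromatic carbon. That change produced a 1.4-fold higher number from compound 2 to compound 1 (0.16 log units; within the scatter). Compound 3 differs from compound 2 by trifluoromethyl in place of methyl on an aromatic carbon; this is also how the cores of the two pairs differ. That change produced a 1.7-fold lower number from compound 2 to compound 3 (0.23 log units; within the scatter). Compound 3 carries the lowest of the three numbers, yet its distance to compound 2 is within the scatter, so no order between those two is claimed; only the gap from compound 3 to compound 1 is beyond the scatter.

Compound 4 differs from compound 3 by fluoro in place of trifluoromethyl on an aromatic carbon. Within the data shown here, this is the same kind of change as the one from compound 2 to compound 1, not the same one: there the changed position is described as ortho to a large group, here as para to a large group. Among the measured compounds shown here, the single precedent for this kind of change is the step of a 1.4-fold higher number from compound 2 to compound 1 (0.16 log units; within the scatter), which lay within the scatter. On that basis the expected step is a 1.4-fold higher number from compound 3 to compound 4 (0.15 log units; within the scatter). Compound 4 is accordingly estimated at 2400 nM in this assay, with a likely range from 1200 nM to 4800 nM.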

Compound 4, half-maximal inhibitory concentration: 2340 nM
The estimate for compound 4 lay 1.0-fold (0.01 log units) above the measured number; low and high end bracket the measured number.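

In this assay, fluoro in place of trifluoromethyl gives a 1.4-fold higher number from compound 3 to compound 4 (0.14 log units; within the scatter) and so sits level with the earlier step on the other core: the same change on two cores in this assay, a 1.4-fold higher number (0.16 log units; within the scatter) from compound 2 to compound 1 and a 1.4-fold higher number (0.14 log units; within the scatter) from compound 3 to compound 4, 1.0-fold (0.02 log units) apart, within the scatter of two such steps

On these two cores the change therefore carries over without a readable difference, but both steps lie within the scatter, so what transfers is the absence of a resolved effect rather than a demonstrated shift, and two pairs make no rule for the series. Fluoro in place of methyl, seen in a 1.3-fold lower number from compound 2 to compound 4 (0.10 log units; within the scatter) as a further step within the scatter, gives no order for that pair either.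

The compounds shown leave open whether a change large enough to pass beyond the scatter would carry from one core to another in the same way, since neither step here offers such a test. What an amine, a carboxylic acid or a longer chain would do in place of the fluoro of the 4-fluorophenyl group also stays open, as the groups shown at that place are limited to methyl, trifluoromethyl and fluoro.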